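Amino to dimethylamino on the pyridyl ring of compound 3

A few compounds are considered here, and "the series" means these few. Any claim that something is new, unique, unknown or untested is made for them only; others in the source may bear on it.

Going by the values given here, compound 3 `CCCN(CCC)c1cc(C)nc2c(-c3ncc(C)cc3N)c(C)nn12` stands highest of the three numbers so far in an assay on isolated protein for binding affinity to corticotropin-releasing factor receptor 1 (Homo sapiens) (on this read-out lower numbers stand for stronger inhibition and higher numbers for weaker inhibition), where compound 3 gives 40 nM. Compound 1 `CCCN(CCC)c1cc(C)nc2c(-c3ncc(C)cc3[N+](=O)[O-])c(C)nn12` gives 14 nM and compound 2 `CCCN(CCC)c1cc(C)nc2c(-c3ncc(F)cc3C)c(C)nn12` gives 19 nM. Both measured steps run toward compound 3: a 2.9-fold higher number from compound 1 to compound 3 (0.46 log units; beyond the scatter) and a 2.1-fold higher number from compound 2 to compound 3 (0.32 log units; beyond the scatter), each beyond the scatter, each modest. Compound 4 `CCCN(CCC)c1cc(C)nc2c(-c3ncc(C)cc3N(C)C)c(C)nn12` takes the same position further: dimethylamino in place of amino on an aromatic carbon. The donor of the amino group is thus removed, and the substituent grows. Neither measured step covers a dimethylamino group directly; what they show is that the amino-bearing compound 3 sits at the weak end, while the nitro of compound 1 and the fluoro-methyl pyridyl of compound 2 sit lower. On that basis a move back toward the lower numbers is expected in this assay for compound 4, of modest size, because the two changes away from compound 3 both read lower by a 2.9-fold higher number from compound 1 to compound 3 (0.46 log units; beyond the scatter) and a 2.1-fold higher number from compound 2 to compound 3 (0.32 log units; beyond the scatter). Compound 4 is expected at 20 nM, with a range from 6 nM to 70 nM, meaning an estimated 2.0-fold lower number from compound 3 to compound 4 (0.30 log units; within the scatter).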

Compound 4, inhibition constant: 23 nM
Estimate against measurement, compound 4: 1.2-fold (0.06 log units) below; low and high end bracket the measured number.
By their numbers in this assay, from the lowest: compounds 1, 2, 4 and 3 (each within the scatter of the next, the first and the last beyond it).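

In this assay, dimethylamino in place of amino gives a 1.7-fold lower number from compound 3 to compound 4 (0.24 log units; within the scatter): on this aromatic carbon, ortho to a large group, losing the hydrogen-bond donor of amino and enlarging the substituent produces no difference that can be read. Dimethylamino in place of nitro gives a 1.6-fold higher number from compound 1 to compound 4 (0.22 log units; within the scatter), so compound 4 cannot be told from either of the two compounds that remain apart by a 2.9-fold higher number from compound 1 to compound 3 (0.46 log units; beyond the scatter). The data offer no measured property of these groups that would account for these numbers.

Still open, from the compounds shown here alone, is whether methylamino or methoxy on the same aromatic carbon would fall within this narrow range, or whether a larger group such as morpholine would move the number beyond the scatter. An acetamide there would show whether a group carrying an amide hydrogen reads like amino or like dimethylamino.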